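From a hydroxymethyl ring to an open carboxymethyl amine

A few compounds are considered here, and "the series" means these few. Any claim that something is new, unique, unknown or untested is made for them only; others in the source may bear on it.

Compound 1 `CCN(CC)Cc1c(O)c([C@H]2CCN(C)C[C@H]2O)c2oc(C)cc(=O)c2c1O`: 27%
Compound 2 `Cc1cc(=O)c2c(O)c(CN3CCCC3)c(O)c([C@H]3CCN(C)C[C@H]3O)c2o1`: 28%
Compound 3 `Cc1cc(=O)c2c(O)c(CN3CCCC3CO)c(O)c([C@H]3CCN(C)C[C@H]3O)c2o1`: 13%

In a functional assay on MIA PaCa-2 cells (Homo sapiens) for inhibition, read by MTT assay, with a stated time of 48 h, tested at 10 uM (on this read-out lower numbers stand for less inhibition of growth and higher numbers for more inhibition of growth at the one concentration tested), compound 3 stands lowest of the three. Compound 4 `Cc1cc(=O)c2c(O)c(CN(C)CC(=O)O)c(O)c([C@H]3CCN(C)C[C@H]3O)c2o1` shares its core and differs as follows: (carboxymethyl)(methyl)amino in place of 2-(hydroxymethyl)pyrrolidin-1-yl on a saturated chain carbon bound to an aromatic carbon. The closest evidence is the pair of modest falls, a number 14 percentage points lower from compound 1 to compound 3 (beyond the scatter) and a number 15 percentage points lower from compound 2 to compound 3 (beyond the scatter), both seen when the hydroxymethyl-bearing ring entered, while a number 1 percentage points higher from compound 1 to compound 2 (within the scatter) shows that the plain amine swap hardly registered. Among the measured compounds shown here, no compound with the carboxymethyl group has been measured, so the entering group's effect is unknown. Only a small change is therefore expected, with no step beyond the scatter. The estimated change is a number 3 percentage points higher from compound 3 to compound 4 (within the scatter). Compound 4 is expected at 16%, within 4% to 30%.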

Compound 4, percent growth inhibition at one concentration: 16%
The estimate for compound 4 equals the measured number at the digits printed; measured number inside the range.
By their numbers in this assay, from the lowest: compounds 3 and 4 (each within the scatter of the next); then compounds 1 and 2 (each within the scatter of the next).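

In this assay, (carboxymethyl)(methyl)amino in place of 2-(hydroxymethyl)pyrrolidin-1-yl on a saturated chain carbon bound to an aromatic carbon gives a number 3 percentage points higher from compound 3 to compound 4 (within the scatter), so opening the ring and introducing the acid leaves the two compounds indistinguishable. The same group gives a number 12 percentage points lower from compound 2 to compound 4 (beyond the scatter) and a number 11 percentage points lower from compound 1 to compound 4 (beyond the scatter), which places both oxygen-bearing amines shown, one cyclic and one open, under the two plain amines. No measured evidence here explains this difference. The compounds shown leave open whether a methyl ester or primary amide of the carboxymethyl group would group with compound 3 and compound 4 or with compound 1 and compound 2. On these data alone, a longer chain carrying the carboxylic acid remains equally open.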